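Bromo for methoxy on the anilide ring of compound 1

The source may hold more compounds than are shown below. What is called first, only, known or untested is meant among the compounds shown, and "the series" means these compounds.

Compound 1 `COc1cccc(NC(=O)c2ccc3cccc(O)c3n2)c1`: 2.5
Compound 2 `Cc1ccccc1NC(=O)c1ccc2cccc(O)c2n1`: 2.5
Compound 3 `O=C(Nc1cccc(F)c1)c1ccc2cccc(O)c2n1`: 2.5

In a physicochemical assay for lipophilicity, read by HPLC (on this read-out lower numbers stand for lower lipophilicity and higher numbers for higher lipophilicity), compound 1 gives 2.5, level with compounds 2 and 3. The step of no change at the digits printed from compound 1 to compound 3 (within the scatter) and the step of no change at the digits printed from compound 2 to compound 3 (within the scatter) both lie within the scatter. Compound 4 `O=C(Nc1cccc(Br)c1)c1ccc2cccc(O)c2n1` differs from compound 1 as follows: bromo in place of methoxy on an aromatic carbon. Going by the values given here, of the measured steps, only the one from compound 1 to compound 3 touches the same aromatic carbon, and it showed no change beyond the scatter; no measured step involves a bromo group. A step of a number 0.40 log units higher from compound 1 to compound 4 (beyond the scatter) is therefore expected, small and upward, but not firmly anchored in the measured steps. Compound 4 is estimated at 2.9, in the range 2.5 to 3.3, in this assay.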

Compound 4, partition coefficient: 2.5
For compound 4 the middle estimate is 0.40 log units above the measured one, and the stated range covers the measured number.
By their numbers in this assay, from the lowest: compounds 1, 2, 3 and 4 (each within the scatter of the next).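

On this aromatic carbon, meta to a large group, bromo now stands alongside methoxy and fluoro, and this assay shows no change at the digits printed from compound 1 to compound 4 (within the scatter) and no change at the digits printed from compound 3 to compound 4 (within the scatter). With 3-bromophenyl in place of 2-methylphenyl on the amide-type nitrogen, the same read-out gives no change at the digits printed from compound 2 to compound 4 (within the scatter). Nothing at hand bears on why these numbers stay level.

The compounds shown leave open whether an amine or a carboxylic acid on this same aromatic carbon would separate from these four in this assay. They also leave open whether a longer chain there would do so.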